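Mirror Image of Compound 3: What to Expect

The compounds below may be only part of what the source reports. "The series", "measured", "known", "first", "only" and "open" are said of these compounds alone.

Measured compounds:
compound 1 `Cc1ccc(CNC(=O)c2[nH]cnc2C(=O)Nc2ccc(Cl)c(Cl)c2)cc1` — 21400 nM
compound 2 `C[C@@H](NC(=O)c1[nH]cnc1C(=O)Nc1ccc(Cl)c(Cl)c1)C(=O)OC(C)(C)C` — 4600 nM
compound 3 `COC(=O)[C@H](NC(=O)c1[nH]cnc1C(=O)Nc1ccc(Cl)c(Cl)c1)C(C)C` — 8500 nM

In a functional assay on HL-60 cells (Homo sapiens), with a stated time of 2 days (on this read-out higher numbers stand for weaker inhibition and lower numbers for stronger inhibition), compound 3 gives the second highest of the three numbers. Its nearest neighbour is compound 2, and the step of a 1.8-fold higher number from compound 2 to compound 3 (0.27 log units; within the scatter) lies within the scatter. Its furthest neighbour is compound 1, and the step of a 2.5-fold lower number from compound 1 to compound 3 (0.40 log units; beyond the scatter) lies beyond it.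

Compound 4 `COC(=O)[C@@H](NC(=O)c1[nH]cnc1C(=O)Nc1ccc(Cl)c(Cl)c1)C(C)C` is the mirror image of compound 3 at its single stereocentre: the two compounds have the same atoms and bonds and differ only in configuration as drawn: 1 of 1 stereo elements differ; a stereocentre at a saturated chain carbon is drawn R in compound 3 and S in compound 4.

Going by the values given here, none of the measured steps bears directly on this change. Each of them, a 4.7-fold lower number from compound 1 to compound 2 (0.67 log units; beyond the scatter), a 2.5-fold lower number from compound 1 to compound 3 (0.40 log units; beyond the scatter) and a 1.8-fold higher number from compound 2 to compound 3 (0.27 log units; within the scatter), swaps the group on the amide-type nitrogen while keeping the configuration as drawn, so the three numbers say nothing about what inversion alone does. Without such a precedent, the expected step of no change at the digits printed from compound 3 to compound 4 (within the scatter) is set at none beyond the scatter, but with a wide range either way. Compound 4 is therefore estimated at 8500 nM in this assay, between 2500 nM and 30000 nM.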

Compound 4, half-maximal inhibitory concentration: > 62500 nM
Compound 4: only a limit was reported (the forecaster's own chance of this, stated with the estimate: 5%); at least 7.3-fold (0.86 log units) between middle value and limit.
By their numbers in this assay, from the lowest: compounds 2 and 3 (each within the scatter of the next); then compound 1. At a limit, above all of these: compound 4.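

In this assay compound 4 gives > 62500 nM as a limit of the assay, not as a number. Inversion alone at this saturated chain carbon gives an at least 7.3-fold higher number from compound 3 to compound 4 (0.86 log units; beyond the scatter) and so matters here in a way the earlier swaps on the amide-type nitrogen could not show: the fact that compounds 3 and 4 differ only in the configuration as drawn. The steps of an at least 13-fold higher number from compound 2 to compound 4 (1.13 log units; beyond the scatter) and an at least 2.9-fold higher number from compound 1 to compound 4 (0.46 log units; beyond the scatter) also place this compound past both other compounds, including the 4-methylbenzyl compound that had given the highest number.

The compounds shown leave open how far the true value of compound 4 lies past its limit, and whether inversion has a similar effect with the 1-(tert-butoxycarbonyl)ethyl group. They also leave open whether a carboxylic acid in place of the methyl ester would keep this difference between the two configurations.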